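Benzyl to methyl exchange on two related cores

A few compounds are considered here, and "the series" means these few. Any claim that something is new, unique, unknown or untested is made for them only; others in the source may bear on it.

Compound 1 `C[Se]/C(=N\C(=O)c1cccs1)NC(=O)c1cccs1` and compound 2 `O=C(/N=C(/NC(=O)c1cccs1)[Se]Cc1ccccc1)c1cccs1` share one core and differ only at a saturated chain carbon bound to a selenium atom: the change is hydrogen in place of phenyl on a saturated chain carbon bound to a selenium atom, read one bond further out as benzyl to methyl. In a functional assay on K562 cells (Homo sapiens) for cytotoxicity, read by MTT assay, with a stated time of 72 h (on this read-out lower numbers stand for stronger inhibition of growth and higher numbers for weaker inhibition of growth), compound 1 gives 6070 nM, while compound 2 gives 29500 nM; the change produced a 4.9-fold lower number from compound 2 to compound 1 (0.69 log units; beyond the scatter).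

Compound 3 `O=C(/N=C(/NC(=O)c1csc([N+](=O)[O-])c1)[Se]Cc1ccccc1)c1csc([N+](=O)[O-])c1` keeps the benzyl but sits on a second core; how the core of compound 3 differs from the core of compound 2 is not broken down here. In this assay compound 3 gives 23500 nM, which lies within the scatter of the number for compound 2.

Compound 4 `C[Se]/C(=N\C(=O)c1csc([N+](=O)[O-])c1)NC(=O)c1csc([N+](=O)[O-])c1` is the methyl counterpart of compound 3, the change being (hydrogen in place of phenyl on a saturated chain carbon bound to a selenium atom), the same change as from compound 2 to compound 1. The step to compound 4 in this assay is expected to be a 4.9-fold lower number from compound 3 to compound 4 (0.69 log units; beyond the scatter), because the same change on the first core gave a 4.9-fold lower number from compound 2 to compound 1 (0.69 log units; beyond the scatter). Compound 4 is therefore estimated at 4800 nM, with a range from 2000 nM to 12000 nM.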

Compound 4, concentration for 50% growth inhibition: 4980 nM
For compound 4 the middle estimate is 1.0-fold (0.02 log units) below the measured one; measured number inside the range.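

In this assay the benzyl to methyl exchange on the core of compound 3 gives a 4.7-fold lower number from compound 3 to compound 4 (0.67 log units; beyond the scatter) and matches the step seen on the other core: the same change on two cores in this assay, a 4.9-fold lower number (0.69 log units; beyond the scatter) from compound 2 to compound 1 and a 4.7-fold lower number (0.67 log units; beyond the scatter) from compound 3 to compound 4, 1.0-fold (0.01 log units) apart, within the scatter of two such steps.

Within these four compounds the change therefore carries from one core to the other with its size kept, and neither pair goes against this. Going by these compounds alone, the finding rests on only two pairs, one change and one read-out, so it sets no rule for cores beyond these two and does not explain why the methyl compounds give the lower numbers.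

The compounds shown leave open how the numbers run between methyl and benzyl, for example with an ethyl group or a longer chain on the selenium atom. Also open, from the compounds shown here alone, is whether an amine or a carboxylic acid at the end of such a chain would keep the numbers near those of compound 1 and compound 4.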